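Ester aryl variation on the acrylate series: trimethoxy step

This account rests on a few compounds, and the source may have more. Where it says the series, first, only, none or still open, it means among the compounds named here.

Compound 1 `COC(=O)/C(=C\c1ccc(OC(=O)c2ccccc2)cc1)Sc1ccnc2cc(Cl)ccc12` carries a plain phenyl on the ester carbonyl carbon; in a functional assay on Jurkat E6.1 cells (Homo sapiens) for cytotoxicity, read by MTT assay, with a stated time of 24 h (on this read-out higher numbers stand for weaker inhibition and lower numbers for stronger inhibition), compound 1 gives 35700 nM. Compound 2 `COC(=O)/C(=C\c1ccc(OC(=O)c2c(OC)cccc2OC)cc1)Sc1ccnc2cc(Cl)ccc12` differs only by 2,6-dimethoxyphenyl in place of phenyl on that carbonyl carbon, and in this assay compound 2 gives 37500 nM. The step of a 1.1-fold higher number from compound 1 to compound 2 (0.02 log units; within the scatter) lies within the scatter, so the two numbers are not distinguished; compound 2 is simply one of two equivalent readings, with compound 1 as its nearest neighbour.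

Compound 3 `COC(=O)/C(=C\c1ccc(OC(=O)c2cc(OC)cc(OC)c2OC)cc1)Sc1ccnc2cc(Cl)ccc12` is not yet measured. Its change from compound 2 is 2,3,5-trimethoxyphenyl in place of 2,6-dimethoxyphenyl on a carbonyl carbon, that is, another methoxy-bearing aryl on the same carbonyl carbon. Within the data shown here, the only step that bears on this position, a 1.1-fold higher number from compound 1 to compound 2 (0.02 log units; within the scatter), added two methoxy groups to the aryl and moved the number by nothing beyond the scatter. On that single precedent, no step beyond the scatter is expected for this assay, and the estimated step is a 1.0-fold lower number from compound 2 to compound 3 (0.01 log units; within the scatter). Compound 3 is therefore expected to give about 37000 nM, with a range from 18000 nM to 75000 nM.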

Compound 3, half-maximal inhibitory concentration: 15600 nM
Beside the measured number, compound 3's estimate is 2.4-fold (0.38 log units) above it, and the stated range ends above it.
By their numbers in this assay, from the lowest: compound 3; then compounds 1 and 2 (each within the scatter of the next).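

In this assay, the aryl group on the carbonyl carbon can move the number after all: 2,3,5-trimethoxyphenyl in place of 2,6-dimethoxyphenyl gives a 2.4-fold lower number from compound 2 to compound 3 (0.38 log units; beyond the scatter), a modest step beyond the scatter, which the earlier change on this carbon did not produce. The same group in place of phenyl gives a 2.3-fold lower number from compound 1 to compound 3 (0.36 log units; beyond the scatter), so compound 3 stands apart from both earlier compounds, while compound 2 shows that carrying methoxy groups on this aryl is not by itself enough for a lower number. Nothing available explains why this particular aryl group shifts the number.

Compound 3 differs from compound 2 in both the number and the placing of its methoxy groups, so the compounds shown cannot separate these two changes, and a single further step in the same direction is not implied by this one. Also open, on these data alone, is how this position responds to substituents other than methoxy on the aryl group, such as an amine or a carboxylic acid, or to replacing the aryl group with a longer alkyl chain.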